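A few compounds are considered here, and "the series" means these few. Any claim that something is new, unique, unknown or untested is made for them only; others in the source may bear on it.

Compound 1 `O=c1c(-c2nn[nH]n2)c[nH]c2c(F)cccc12` is the stronger of the two measured compounds in a functional assay on the whole organism (strain Sprague-Dawley) for inhibition, with Rattus norvegicus as the target; a lower number here means that less compound is needed, a higher number that more compound is needed for the effect: compound 1 needs 0.625 mg/kg, the lowest of the two numbers. Compound 2 `Cc1cc(F)c2[nH]cc(-c3nn[nH]n3)c(=O)c2c1` carries a methyl in place of hydrogen on an aromatic carbon, and in this assay compound 2 needs 2.5 mg/kg; that is a 4.0-fold higher number from compound 1 to compound 2 (0.60 log units; beyond the scatter).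

Compound 3 `Cc1cccc2c(=O)c(-c3nn[nH]n3)c[nH]c12` differs from compound 1 by methyl in place of fluoro on an aromatic carbon. Within the data shown here, only one measured step speaks to this change, the step from compound 1 to compound 2, where adding a methyl on an aromatic carbon of the core raised the dose modestly. Here the methyl enters at a different place and a fluoro leaves at the same time, so that step is an imperfect guide. A rise of similar or smaller size, in the direction of a higher dose, is therefore expected; a 2.0-fold higher number from compound 1 to compound 3 (0.30 log units; within the scatter) is the step this estimate implies. Compound 3 is expected to need about 1.25 mg/kg, between 0.625 mg/kg and 2.5 mg/kg.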

Compound 3, minimum effective dose: > 5 mg/kg
Compound 3: no number, only a limit (the forecaster's own chance of this, stated with the estimate: 5%); middle value at least 4.0-fold (0.60 log units) away from the limit.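

The earlier step from compound 1 to compound 2 kept the fluoro and added a methyl elsewhere on the core, so it said nothing about replacing the fluoro itself. In this assay, putting methyl in place of that fluoro gives an at least 8.0-fold higher number from compound 1 to compound 3 (0.90 log units; beyond the scatter), so this position does not accept the swap without a clear rise in the dose needed. The result for compound 3 is a limit of the assay and not a number, which makes the step a lower bound on the real change: the limit of > 5 mg/kg in this assay, at which 1 of the 3 values shown sits.

Going by these compounds, how much more compound 3 would need stays open, as does whether the rise comes from losing the fluoro or from adding the methyl. Plain hydrogen, chloro or methoxy on this same carbon could help separate these two readings.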